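Aryl amine in place of benzyl amine on the shared core

The compounds below may be only part of what the source reports. "The series", "measured", "known", "first", "only" and "open" are said of these compounds alone.

Compound 2 `Cc1ccc(CNc2nc(Nc3ccc(N4CCN(C)CC4)cn3)ncc2Cl)cc1` gives in an ADME assay on L02 cells (Homo sapiens) for inhibition, read by CCK-8 assay, with a stated time of 48 h (a lower number here means a stronger inhibitor of growth, a higher number a weaker inhibitor of growth), only a limit, namely > 100000 nM. It therefore sits at the limit of > 100000 nM in this assay, at which 1 of the 2 values shown sits, and no number is available for it. The second measured member, compound 1 `Cc1ccccc1Nc1nc(Nc2ccc(N3CCNCC3)cn2)ncc1Cl`, gives in this assay a value of 1850 nM. Within the data shown here, compound 1 differs from compound 2 in more than one place, so no single step joins them; the pair shows only that one member of the series gives a number while the other gives a limit.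

Compound 3 `Cc1cc(C)c(Nc2nc(Nc3ccc(N4CCN(C)CC4)cn3)ncc2Cl)c(C)c1` is not yet measured. It differs from compound 2 in one place: 2,4,6-trimethylphenyl in place of 4-methylbenzyl on a nitrogen on an aromatic ring. Among the measured compounds shown here, no measured step of this kind exists. In this assay, for the measured compounds named here, the step from compound 2 to compound 3 is expected to be large and toward stronger growth inhibition, an at least 12-fold lower number from compound 2 to compound 3 (1.09 log units; beyond the scatter), since compound 1, the one member of the series with a number, gives 1850 nM. Compound 3 is accordingly estimated at 8000 nM, with a range from 1500 nM to 60000 nM.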

Compound 3, concentration for 50% growth inhibition: 20500 nM
Beside the measured number, compound 3's estimate is 2.6-fold (0.41 log units) below it; the range from low to high includes it.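

In this assay, among these compounds, the change from 4-methylbenzyl to 2,4,6-trimethylphenyl on a nitrogen on an aromatic ring gives an at least 4.8-fold lower number from compound 2 to compound 3 (0.68 log units; beyond the scatter), the only step that joins two compounds differing in one place. With the rest of compound 2 unchanged, this single change turns a limit into a number, so this position bears on the read-out, which compound 1 could not show, differing from compound 2 in more than one place. The size of the step remains a lower bound, as the value for compound 2 is a limit and not a number: the limit of > 100000 nM in this assay, at which 1 of the 3 values shown sits.

The step does not separate the loss of the carbon link between the ring and the amine nitrogen from the addition of methyl groups on the ring, and compound 1 and compound 3 differ in more than one place, so their values do not settle this. From the compounds shown here alone, how a plain phenyl, a 4-methylphenyl or a cyclohexyl on the same nitrogen would read in this assay also stays open.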